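Pentan-3-yl in place of butyl on the imine nitrogen

The compounds below may be only part of what the source reports. "The series", "measured", "known", "first", "only" and "open" are said of these compounds alone.

Measured compounds:
Compound 1, `CC(/N=c1\c(O)c(O)\c1=N/[C@H](C)C(C)(C)C)c1ccc(C#N)cc1`: 6500 nM
Compound 2, `CCCC/N=c1\c(O)c(O)\c1=N/Cc1ccc(C#N)cc1`: > 30000 nM
Compound 3, `CCC(C)(C)/N=c1\c(O)c(O)\c1=N/Cc1c(C)cc(C#N)cc1Cl`: 160 nM

All three share one core and were tested in a functional assay for inhibition, with Rattus norvegicus as the target; a higher number here means a weaker inhibitor, a lower number a stronger inhibitor. Compound 2 gives only a limit of the assay, > 30000 nM, so its true value is unknown and it stands at the weak end of what is shown. The other two compounds carry different groups on the same nitrogen and, in compound 3, further changes on the aromatic ring; compound 1 gives 6500 nM and compound 3 gives 160 nM. This is noted as the limit of > 30000 nM in this assay, at which 1 of the 3 values shown sits.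

Compound 4, `CCC(CC)/N=c1\c(O)c(O)\c1=N/Cc1ccc(C#N)cc1`, has not yet been measured. It differs from compound 2 in one place: pentan-3-yl in place of butyl on a double-bonded nitrogen. Going by the values given here, no step between measured compounds matches this exact change, so the expected size rests on what compound 1 and compound 3 show, namely that the two compounds without a butyl group on that nitrogen give numbers rather than a limit.

The step of an at least 3.7-fold lower number from compound 2 to compound 4 (0.57 log units; beyond the scatter) is therefore expected to move toward stronger inhibition, beyond the scatter, but with wide uncertainty. Compound 4 is estimated at 8000 nM, within a range from 1500 nM to 40000 nM, and a limit remains possible.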

Compound 4, half-maximal inhibitory concentration: 1300 nM
Compound 4: the middle estimate sits 6.2-fold (0.79 log units) above what was measured; measured number outside the range, below it.
By their numbers in this assay, from the lowest: compound 3; then compound 4; then compound 1. At a limit, above all of these: compound 2.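

In this assay, replacing butyl with pentan-3-yl on a double-bonded nitrogen, with the rest of the molecule unchanged, gives an at least 23-fold lower number from compound 2 to compound 4 (1.36 log units; beyond the scatter). This pair isolates the group on that nitrogen, which compound 1 and compound 3 could not do because each differs from compound 2 in more than one place, and it shows that this single change is enough to turn a compound with no measured number into one with a clear value. The size of the step is only a minimum, since compound 2 gives a limit and not a number: the limit of > 30000 nM in this assay, at which 1 of the 4 values shown sits.

What remains unclear is whether the gain comes from the extra carbon or from the shape of the new group, a question that a straight pentyl chain or a cyclopentyl ring on the same nitrogen could help to answer. As far as these compounds go, it is also open whether pentan-3-yl would give a similar gain in a compound carrying the chlorine and methyl groups found on the aromatic ring of compound 3.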